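The source may hold more compounds than are shown below. What is called first, only, known or untested is meant among the compounds shown, and "the series" means these compounds.

Of the compounds shown here, two with a shared core have been tested in a functional assay on A549 cells (Homo sapiens) for antiproliferative activity, read by MTT assay, with a stated time of 48 h; a higher number here means a weaker inhibitor, a lower number a stronger inhibitor. Compound 1 `Cn1cc(C2=C(c3nn(CCCn4cncn4)c4ncccc34)C(=O)N(c3ccccc3)C2=O)c2ccccc21` gives > 100000 nM, which is a limit of the assay and not a number. Compound 2 `COc1ccc(N2C(=O)C(c3cn(C)c4ccccc34)=C(c3nn(CCCN4CCCCC4)c4ncccc34)C2=O)cc1` differs from compound 1 in more than one place. Among the compounds with values here, compound 2 gives 30300 nM, the only true number so far in this assay.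

Compound 3 `Cn1cc(C2=C(c3nn(CCCCn4ccnc4)c4ncccc34)C(=O)N(c3ccccc3)C2=O)c2ccccc21` departs from compound 1 in the side chain alone: (1H-imidazol-1-yl)methyl in place of 1H-1,2,4-triazol-1-yl on a saturated chain carbon, three bonds along the chain from an aromatic nitrogen. In words, (1H-imidazol-1-yl)methyl stands in place of 1H-1,2,4-triazol-1-yl on a saturated chain carbon, three bonds along the chain from an aromatic nitrogen, which can also be read as 3-(1H-1,2,4-triazol-1-yl)propyl to 4-(1H-imidazol-1-yl)butyl. Within the data shown here, no measured pair isolates a change of this kind, so the expectation is loose. A modest move toward stronger inhibition in this assay is expected, and compound 3 may well remain a weak inhibitor, with compound 2 at 30300 nM as the nearest guide. The expected step is an at least 1.8-fold lower number from compound 1 to compound 3 (0.25 log units; that floor lies within the scatter). For compound 3 the estimated value is 55000 nM, with an expected range of 20000 nM to 100000 nM.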

Compound 3, half-maximal inhibitory concentration: 21700 nM
The estimate for compound 3 lay 2.5-fold (0.40 log units) above the measured number; low and high end bracket the measured number.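

In this assay, within the data shown here, the move from 3-(1H-1,2,4-triazol-1-yl)propyl to 4-(1H-imidazol-1-yl)butyl gives an at least 4.6-fold lower number from compound 1 to compound 3 (0.66 log units; beyond the scatter), the first reading of a change made in one place, on a saturated chain carbon, three bonds along the chain from an aromatic nitrogen. Compound 3 gives 21700 nM, so a side chain change alone on the shared core is enough to bring a true number in this assay. That step can be stated only as a floor, and its full size stays unknown, because compound 1 stands at a limit of the assay and not at a number: the limit of > 100000 nM in this assay, at which 1 of the 3 values shown sits.

The change swaps the ring and lengthens the chain together, so the compounds shown cannot tell which of the two carries the step; a 3-(1H-imidazol-1-yl)propyl or a 4-(1H-1,2,4-triazol-1-yl)butyl side chain would separate them. They also leave open how a still longer chain ending in imidazole, or a morpholine at the end of the chain, would read on this core.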